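Methoxymethyl for sec-butyl on the chain carbon

This account rests on a few compounds, and the source may have more. Where it says the series, first, only, none or still open, it means among the compounds named here.

Measured so far in a functional assay on MCF7 cells (Homo sapiens) for antiproliferative activity; on this read-out higher numbers stand for weaker inhibition and lower numbers for stronger inhibition:
compound 1, `CCn1c(Cc2cc(OC)c(OC)c(OC)c2)nc2c(N)ncnc21`, 79400 nM
compound 2, `CC[C@H](C)Cn1c(Cc2cc(OC)c(OC)c(OC)c2)nc2c(N)nc(F)nc21`, 43700 nM
compound 3, `COc1cc(Cc2nc3c(N)ncnc3n2CC2(C)CC2)cc(OC)c1OC`, 112000 nM

Compound 2 holds the lowest of the three numbers in this assay . Its number and that of compound 1 lie within the scatter of each other, so no order is drawn between them; compound 3 sits beyond the scatter at the higher side.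

The step to compound 4, `COCCn1c(Cc2cc(OC)c(OC)c(OC)c2)nc2c(N)nc(F)nc21`, exchanges the chain on the aromatic nitrogen: methoxymethyl in place of sec-butyl on a saturated chain carbon bound to an aromatic nitrogen. Within the data shown here, the only measured step at the same place is a 1.4-fold higher number from compound 1 to compound 3 (0.15 log units; within the scatter), where a larger saturated group entering on that chain carbon left the number within the scatter. Among the measured compounds shown here, the present change goes the other way in size and brings in an oxygen, for which no measured pair exists; the shared core of compound 2 with its fluorine is otherwise kept. Given that the one step at this position stayed within the scatter, the expectation for compound 4 in this assay is a small shift, if any, with a slight lean to a higher number, as a 1.4-fold higher number from compound 2 to compound 4 (0.14 log units; within the scatter). Compound 4 is therefore estimated at 60000 nM, between 20000 nM and 180000 nM.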

Compound 4, half-maximal inhibitory concentration: 64600 nM
Compound 4: the middle estimate sits 1.1-fold (0.03 log units) below what was measured, within the range that was stated.
By their numbers in this assay, from the lowest: compounds 2, 4, 1 and 3 (each within the scatter of the next, the first and the last beyond it).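

Read in this assay, the exchange of sec-butyl for methoxymethyl gives a 1.5-fold higher number from compound 2 to compound 4 (0.17 log units; within the scatter). This shows that the chain on the aromatic nitrogen of the fluorine-bearing core can lose the defined stereocentre and take up an oxygen, with its hydrogen-bond acceptor, without a step beyond the scatter. The earlier step at this place, a 1.4-fold higher number from compound 1 to compound 3 (0.15 log units; within the scatter), concerned only a saturated group on the core of compound 1, so the two steps now show a within-scatter outcome for both a saturated and an oxygen-bearing change on a saturated chain carbon bound to an aromatic nitrogen, though on different cores and for these groups alone; nothing at hand gives a reason for this outcome.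

Open, on these data alone, is whether an amine, a carboxylic acid or a longer ether chain at this place would give a step beyond the scatter in this assay. Also open is whether methoxymethyl behaves the same way on the core of compound 1, which lacks the fluorine, and what the fluorine contributes by itself, as no pair shown differs in that one place.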